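Moving the Nitro Group in a Cinnamamide Series

The source may hold more compounds than are shown below. What is called first, only, known or untested is meant among the compounds shown, and "the series" means these compounds.

Compound 1 `COc1ccc(/C=C/C(=O)NCCCCNc2ccnc3cc(Cl)ccc23)cc1` gives 16900 nM in a functional assay on MKN-28 cells (Homo sapiens) for antiproliferative activity, read by sulforhodamine B assay, with a stated time of 2 days (a lower number here means a stronger inhibitor of growth, a higher number a weaker inhibitor of growth), the highest of the three numbers measured, while compound 3 `O=C(/C=C/c1ccccc1[N+](=O)[O-])NCCCCNc1ccnc2cc(Cl)ccc12` gives 15100 nM and compound 2 `O=C(/C=C/c1ccc(F)cc1)NCCCCNc1ccnc2cc(Cl)ccc12` gives 11800 nM, both within the scatter of that first number. Compound 4 `O=C(/C=C/c1cccc([N+](=O)[O-])c1)NCCCCNc1ccnc2cc(Cl)ccc12` differs from compound 1 by 3-nitrophenyl in place of 4-methoxyphenyl on a double-bonded chain carbon bound to a double-bonded chain carbon. For the measured compounds named here, the steps that bear on this change are a 1.1-fold lower number from compound 1 to compound 3 (0.05 log units; within the scatter) and a 1.3-fold higher number from compound 2 to compound 3 (0.11 log units; within the scatter), and a 1.4-fold lower number from compound 1 to compound 2 (0.16 log units; within the scatter) falls in the same band. Because a 1.1-fold lower number from compound 1 to compound 3 (0.05 log units; within the scatter) stayed within the scatter, compound 4 is expected to sit close to compound 1, with a 1.1-fold lower number from compound 1 to compound 4 (0.05 log units; within the scatter) and no step beyond the scatter. The estimate for compound 4 is 15000 nM, ranging from 7000 nM to 32000 nM.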

Compound 4, concentration for 50% growth inhibition: 16200 nM
Beside the measured number, compound 4's estimate is 1.1-fold (0.03 log units) below it, and the stated range covers the measured number.
By their numbers in this assay, from the lowest: compounds 2, 3, 4 and 1 (each within the scatter of the next).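

In this assay, moving the nitro group to give 3-nitrophenyl in place of 2-nitrophenyl produced a 1.1-fold higher number from compound 3 to compound 4 (0.03 log units; within the scatter), so the two nitrophenyl groups could not be told apart on this double-bonded chain carbon. The 3-nitrophenyl group also stayed level with the other two groups, with a 1.0-fold lower number from compound 1 to compound 4 (0.02 log units; within the scatter) and a 1.4-fold higher number from compound 2 to compound 4 (0.14 log units; within the scatter). Nothing available offers an explanation for this flat result. As far as these compounds go, it remains open whether an amine or a carboxylic acid in place of the nitro group would give a step beyond the scatter.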